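Adding a Second Methoxy Group: Expected Effect on Compound 4

The source may report more compounds than this note shows. Statements on the series, on what has been measured and on what is new or still open speak of the compounds shown alone.

Compound 1 `COc1cc(CNC(=O)/C=C/c2ccc(O)cc2)ccc1OCc1nc(C)c(C)nc1C`: 3740 nM
Compound 2 `COc1cc(/C=C/C(=O)NCc2ccc(OCc3nc(C)c(C)nc3C)c(OC)c2)ccc1O`: 13400 nM
Compound 3 `COc1ccccc1/C=C/C(=O)NCc1ccc(OCc2nc(C)c(C)nc2C)c(OC)c1`: 7150 nM

All three were tested in a functional assay on SH-SY5Y cells (Homo sapiens) for cytotoxicity, read by MTT assay, with stated times of 24 h and 4 h; on this read-out lower numbers stand for an effect already at smaller amounts and higher numbers for an effect only at larger amounts of compound. Compound 3 gives the second highest of the three numbers, but its gaps to its neighbours, a 1.9-fold higher number from compound 1 to compound 3 (0.28 log units; within the scatter) and a 1.9-fold lower number from compound 2 to compound 3 (0.27 log units; within the scatter), both lie within the scatter, so the three cannot be ranked with confidence. Compound 4 `COc1cc(CNC(=O)/C=C/c2cccc(OC)c2OC)ccc1OCc1nc(C)c(C)nc1C` differs from compound 3 by methoxy in place of hydrogen on an aromatic carbon. Among the measured compounds shown here, the only measured step of the same kind, a 3.6-fold higher number from compound 1 to compound 2 (0.55 log units; beyond the scatter), was modest but beyond the scatter, pointing towards a higher number when a methoxy replaces an aromatic hydrogen. A similar step is therefore expected from compound 3 to compound 4, namely a 2.2-fold higher number from compound 3 to compound 4 (0.35 log units; beyond the scatter). Compound 4 is estimated at 16000 nM, with a range from 6000 nM to 40000 nM.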

Compound 4, half-maximal effective concentration: 7150 nM
For compound 4 the middle estimate is 2.2-fold (0.35 log units) above the measured one; the measured number falls inside the stated range.
By their numbers in this assay, from the lowest: compounds 1, 3, 4 and 2 (each within the scatter of the next, the first and the last beyond it).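

In this assay, methoxy in place of hydrogen on an aromatic carbon, here ortho to a methoxy group, gives no change at the digits printed from compound 3 to compound 4 (within the scatter), so this change does not have one fixed size across the two cores: the same change on two cores in this assay, a 3.6-fold higher number (0.55 log units; beyond the scatter) from compound 1 to compound 2 and no change at the digits printed (within the scatter) from compound 3 to compound 4, 3.6-fold (0.55 log units) apart, beyond the scatter of two such steps Swapping the 4-hydroxy-3-methoxyphenyl or the 4-hydroxyphenyl for 2,3-dimethoxyphenyl stays within the scatter, with a 1.9-fold lower number from compound 2 to compound 4 (0.27 log units; within the scatter) and a 1.9-fold higher number from compound 1 to compound 4 (0.28 log units; within the scatter).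

From the compounds shown here alone, it remains open whether the hydroxy group carried by compound 1 and compound 2 decides the size of the methoxy step. Also open, going by these compounds, is how an amine or a carboxylic acid in place of this methoxy would read in this assay.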